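This account rests on a few compounds, and the source may have more. Where it says the series, first, only, none or still open, it means among the compounds named here.

Compound 1 `C/C(=C\c1cc(-c2ccc(C)nc2)co1)C(N)=O` and compound 2 `C/C(=C\c1cc(-c2ccc(F)nc2)co1)C(N)=O` share one core. In a functional assay on MCF7 cells (Homo sapiens) for cytotoxicity, read by CCK-8 assay, with a stated time of 24 h (on this read-out lower numbers stand for stronger inhibition and higher numbers for weaker inhibition), compound 1 gives 10200 nM and compound 2 gives 14100 nM. The change between them is fluoro in place of methyl on an aromatic carbon, and it made a 1.4-fold higher number from compound 1 to compound 2 (0.14 log units; within the scatter). Compound 3 `C/C(=C\c1ccc(-c2ccc(C)cc2)o1)C(N)=O` has a different core; how the two cores differ is not broken down here. In this assay compound 3 gives only a limit, > 50000 nM; this is the limit of > 50000 nM in this assay, at which 1 of the 3 values shown sits.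

Compound 4 `C/C(=C\c1ccc(-c2ccc(F)cc2)o1)C(N)=O` is not yet measured and differs from compound 3 by fluoro in place of methyl on an aromatic carbon. This is the same kind of change as between compound 1 and compound 2, but the place is not the same: in compound 1 the ring is a six-membered aromatic ring with 1 nitrogen and the change sits next to the ring nitrogen, whereas in compound 3 the ring is of carbon only. Because compound 1 and compound 2 showed a 1.4-fold higher number from compound 1 to compound 2 (0.14 log units; within the scatter), a similarly small step is expected, namely a step that the limit leaves unreadable from compound 3 to compound 4. Compound 4 is therefore estimated at 60000 nM, within a range from 30000 nM to 150000 nM.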

Compound 4, half-maximal inhibitory concentration: 970 nM
Estimate against measurement, compound 4: 62-fold (1.79 log units) above; measured number below the stated range.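

In this assay, as far as these compounds go, putting fluoro in place of methyl gave an at least 51-fold lower number from compound 3 to compound 4 (1.71 log units; beyond the scatter), so the change did not carry over with the same size from one core to the other: the same change on two cores in this assay, a 1.4-fold higher number (0.14 log units; within the scatter) from compound 1 to compound 2 and an at least 51-fold lower number (1.71 log units; beyond the scatter) from compound 3 to compound 4, at least 71-fold (1.85 log units) apart, beyond the scatter of two such steps Compound 3 stands at a limit and not at a number, so the full size of its step stays unknown: the limit of > 50000 nM in this assay, at which 1 of the 4 values shown sits. These two pairs show that the outcome of this change can depend on the core, but they do not show which feature of the cores is responsible, and two pairs make no rule for the series.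

The compounds shown leave open how chloro, methoxy or an amine would behave in place of fluoro on either core. They also leave open whether the gap between the two steps would hold in other cell lines.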